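Aryl urea series: trifluoromethyl replaced by nitro

A few compounds are considered here, and "the series" means these few. Any claim that something is new, unique, unknown or untested is made for them only; others in the source may bear on it.

Measured compounds
- compound 1 `CCC1(CC)CC(CC)(CC)c2cc(NC(=O)Nc3ccc(OC(F)(F)F)cc3)ccc2O1`: 3000 nM
- compound 2 `CCC1(CC)CC(CC)(CC)c2cc(NC(=O)Nc3ccc(C(F)(F)F)cc3)ccc2O1`: 2000 nM

Both compounds were read in a functional assay on A2780 cells (Homo sapiens) for inhibition, with a stated time of 72 h; on this read-out lower numbers stand for stronger inhibition and higher numbers for weaker inhibition. Compound 2 stands next to compound 1 only, and the two are not separated: the step of a 1.5-fold lower number from compound 1 to compound 2 (0.18 log units; within the scatter) lies within the scatter, so neither is called the more potent.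

Compound 3 `CCC1(CC)CC(CC)(CC)c2cc(NC(=O)Nc3ccc([N+](=O)[O-])cc3)ccc2O1` is not yet measured in this assay. It differs from compound 2 by nitro in place of trifluoromethyl on an aromatic carbon. Among the measured compounds shown here, the one measured step that bears on this position, a 1.5-fold lower number from compound 1 to compound 2 (0.18 log units; within the scatter), also exchanges the group on that aromatic carbon and stays within the scatter. For the measured compounds named here, no measured pair contains a nitro group, so the data give no direction for this change. Consequently no step beyond the scatter is expected for compound 3 in this assay; the expected step is a 1.3-fold higher number from compound 2 to compound 3 (0.10 log units; within the scatter). Compound 3 is therefore estimated at 2500 nM, with a range from 800 nM to 8000 nM.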

Compound 3, half-maximal inhibitory concentration: 2090 nM
The estimate for compound 3 lay 1.2-fold (0.08 log units) above the measured number; low and high end bracket the measured number.
By their numbers in this assay, from the lowest: compounds 2, 3 and 1 (each within the scatter of the next).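

Nitro now joins trifluoromethyl and trifluoromethoxy on this aromatic carbon in this assay, and the exchange for trifluoromethyl reads as a 1.0-fold higher number from compound 2 to compound 3 (0.02 log units; within the scatter), so 4-(trifluoromethyl)phenyl and 4-nitrophenyl are not separated here. The exchange for trifluoromethoxy, a 1.4-fold lower number from compound 1 to compound 3 (0.16 log units; within the scatter), also stays within the scatter, so all three groups lie within the scatter of one another, even though nitro brings 2 hydrogen-bond acceptors and trifluoromethyl brings 0. No evidence is available that bears on this result.

From the compounds shown here alone, what an amine or a carboxylic acid on this aromatic carbon would give remains open, as does whether any replacement here departs from these three groups beyond the scatter. Going by these compounds, it is also open whether the same reading holds on a core other than the shared one.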